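Amide cap variation on a shared bis-indole core

A few compounds are considered here, and "the series" means these few. Any claim that something is new, unique, unknown or untested is made for them only; others in the source may bear on it.

Measured in a functional assay on BGC-823 cells (Homo sapiens) for cytotoxicity, read by MTT assay, with a stated time of 72 h; a lower number here means a stronger inhibitor, a higher number a weaker inhibitor:
compound 1 `CN1[C@@H]2c3[nH]c4ccccc4c3C[C@H]1[C@H](C#N)N1[C@@H](CNC(=O)c3cccc4c3CCCC4)c3[nH]c4ccccc4c3C[C@@H]21`: 3540 nM
compound 2 `CN1[C@@H]2c3[nH]c4ccccc4c3C[C@H]1[C@H](C#N)N1[C@@H](CNC(=O)c3ccc4ccccc4c3)c3[nH]c4ccccc4c3C[C@@H]21`: 1110 nM
compound 3 `CN1[C@@H]2c3[nH]c4ccccc4c3C[C@H]1[C@H](C#N)N1[C@@H](CNC(=O)c3cc4ccccc4[nH]3)c3[nH]c4ccccc4c3C[C@@H]21`: 1690 nM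

Compound 3 stands second highest of the three numbers: it sits within the scatter of compound 2 (a 1.5-fold higher number from compound 2 to compound 3 (0.18 log units; within the scatter)) and is separated from compound 1 by a 2.1-fold lower number from compound 1 to compound 3 (0.32 log units; beyond the scatter). Compound 4 `CN1[C@@H]2c3[nH]c4ccccc4c3C[C@H]1[C@H](C#N)N1[C@@H](CNC(=O)/C=C/c3ccccc3)c3[nH]c4ccccc4c3C[C@@H]21` differs from compound 3 by 2-phenylethenyl in place of 1H-indol-2-yl on a carbonyl carbon. For the measured compounds named here, no measured step exchanges an aryl for an alkenyl group at this carbonyl; the steps at the same carbonyl, a 3.2-fold lower number from compound 1 to compound 2 (0.50 log units; beyond the scatter) and a 2.1-fold lower number from compound 1 to compound 3 (0.32 log units; beyond the scatter), show that changing this cap moved this assay only modestly. The step of a 1.1-fold higher number from compound 3 to compound 4 (0.03 log units; within the scatter) is therefore expected to be small, plausibly not beyond the scatter in either direction. Compound 4 is estimated at 1800 nM, with a range of 700 nM to 4500 nM.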

Compound 4, half-maximal inhibitory concentration: 4300 nM
Beside the measured number, compound 4's estimate is 2.4-fold (0.38 log units) below it; measured number inside the range.
By their numbers in this assay, from the lowest: compounds 2 and 3 (each within the scatter of the next); then compounds 1 and 4 (each within the scatter of the next).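

In this assay, for the compounds shown here, the cap on this carbonyl now spans a wider range than the earlier compounds showed: 2-phenylethenyl in place of 1H-indol-2-yl gives a 2.5-fold higher number from compound 3 to compound 4 (0.41 log units; beyond the scatter) and in place of naphthalen-2-yl gives a 3.9-fold higher number from compound 2 to compound 4 (0.59 log units; beyond the scatter). In place of 1,2,3,4-tetrahydronaphthalen-5-yl the same group gives a 1.2-fold higher number from compound 1 to compound 4 (0.08 log units; within the scatter) and these two caps remain unseparated. No measurement at hand bears on the reason for these steps.

Open, from the compounds shown here alone, is how a cap carrying an amine or a carboxylic acid, or a longer saturated chain, would stand at this carbonyl.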